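This account rests on a few compounds, and the source may have more. Where it says the series, first, only, none or still open, it means among the compounds named here.

Measured in a functional assay on the whole organism with Mus musculus as the target, in the maximal electroshock model; on this read-out higher numbers stand for an effect only at larger amounts of compound and lower numbers for an effect already at smaller amounts:
- compound 1 `CNC(=O)[C@@H](CO)NCc1ccc(OCc2cccc(C)c2)cc1`: 30.6 mg/kg
- compound 2 `CNC(=O)[C@@H](CO)NCc1ccc(OCc2ccccc2F)cc1`: 19.8 mg/kg

In this assay, compound 2 stands at 19.8 mg/kg and compound 1 at 30.6 mg/kg, so the two values lie within the scatter of each other. The next compound, compound 3 `CNC(=O)[C@@H](CO)NCc1ccc(OCc2cccc(F)c2)cc1`, keeps the shared core of compound 2 and differs from it in one group: 3-fluorophenyl in place of 2-fluorophenyl on a saturated chain carbon bound to an oxygen on an aromatic ring. The two structures hold the same atoms, joined differently, and the change can equally be read as 2-fluorobenzyl to 3-fluorobenzyl.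

For the measured compounds named here, no measured step shows this exchange itself. The only one that bears on it is a 1.5-fold lower number from compound 1 to compound 2 (0.19 log units; within the scatter), which changed the group at the same place, with 2-fluorophenyl replacing 3-methylphenyl. That exchange did not move the number beyond the scatter, so a step beyond the scatter is not expected here either, although a single step is thin evidence. The expected change is a 1.1-fold higher number from compound 2 to compound 3 (0.05 log units; within the scatter). For compound 3 the estimated value is 22 mg/kg, with an expected range from 11 mg/kg to 45 mg/kg.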

Compound 3, dose for half-maximal effect: 13 mg/kg
Beside the measured number, compound 3's estimate is 1.7-fold (0.23 log units) above it; measured number inside the range.
By their numbers in this assay, from the lowest: compounds 3, 2 and 1 (each within the scatter of the next, the first and the last beyond it).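

The exchange of 2-fluorophenyl for 3-fluorophenyl gives a 1.5-fold lower number from compound 2 to compound 3 (0.18 log units; within the scatter) in this assay and so does not separate these two placements of the fluorine on this read-out. For the compounds shown here, the other new pair adds more: fluoro in place of methyl on an aromatic carbon gives a 2.4-fold lower number from compound 1 to compound 3 (0.37 log units; beyond the scatter) and is the first step to pass the scatter, if only modestly, which shows that a small exchange on this ring can register in the read-out even though neither step through compound 2 does so alone. Nothing available accounts for either step.

From the compounds shown here alone, whether a 3-chlorophenyl, a 3-methoxyphenyl or an unsubstituted phenyl at this place would fall with compound 3 or compound 1 remains open, as does the effect of more than one fluorine on the ring. The rest of the shared core is the same in all three compounds, so these results also leave open how a change there, such as an ethyl group in place of the methyl on the amide nitrogen, would act on the read-out.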